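The compounds below may be only part of what the source reports. "The series", "measured", "known", "first", "only" and "open" are said of these compounds alone.

Measured so far, in an assay on CHO cells for displacement of a labelled ligand from adenosine receptor A3 (Homo sapiens); a lower number here means a stronger inhibitor, a higher number a weaker inhibitor: compound 1 `CNc1ncc(C(=O)O)c2nc(-c3ccco3)nn12` gives 15900 nM; compound 2 `CCCCC(CC)CNc1ncc(C(=O)O)c2nc(-c3ccco3)nn12` gives 16400 nM.

Compound 2 stands as the higher of the two numbers, but the gap to compound 1 is within the scatter, so the two compounds are not told apart by this assay. Within the data shown here, the one measured step, a 1.0-fold higher number from compound 1 to compound 2 (0.01 log units; within the scatter), shows that adding a 1-ethylpentyl group on the saturated chain carbon bound to a nitrogen on the aromatic ring left the number essentially where it was.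

Compound 3 `Cc1ccc(CNc2ncc(C(=O)O)c3nc(-c4ccco4)nn23)cc1` differs from compound 2 in one place: 4-methylphenyl in place of 1-ethylpentyl on a saturated chain carbon bound to a nitrogen on an aromatic ring. Among the measured compounds shown here, only the step from compound 1 to compound 2 bears on this change, and it was flat; how a 4-methylphenyl group at that place behaves has not been measured. For compound 3 the step of a 1.4-fold lower number from compound 2 to compound 3 (0.14 log units; within the scatter) is therefore expected to be small, and compound 3 is estimated at 12000 nM, with a range from 4000 nM to 40000 nM.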

Compound 3, inhibition constant: 751 nM
Estimate against measurement, compound 3: 16-fold (1.20 log units) above, outside the stated range (below it).
By their numbers in this assay, from the lowest: compound 3; then compounds 1 and 2 (each within the scatter of the next).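

This position is not indifferent to what it carries. In this assay, 4-methylphenyl gives a 22-fold lower number from compound 2 to compound 3 (1.34 log units; beyond the scatter) and a 21-fold lower number from compound 1 to compound 3 (1.33 log units; beyond the scatter), whereas 1-ethylpentyl had left the number flat. The group that leaves and the group that enters each count 7 heavy atoms, all carbon, with 0 hydrogen-bond donors and 0 acceptors, so in these counts they differ only in the six-membered aromatic ring of carbon only, and no measurement on hand accounts for the step.

The compounds shown leave open whether the ring alone goes with this lower number or whether its methyl group takes part, which a plain benzyl group, or a benzyl group bearing a methoxy group or a chlorine instead of the methyl, would test. Also open, from the compounds shown here alone, is whether the step would hold if an amide replaced the carboxylic acid on the shared core.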